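Cytotoxicity notes on a benzimidazole-anilide series, compound 4 pending

The source may report more compounds than this note shows. Statements on the series, on what has been measured and on what is new or still open speak of the compounds shown alone.

Measured so far:
compound 1 `O=C(CN1CCCC1)Nc1ccc(-c2nc3cc(C(F)(F)F)ccc3[nH]2)cc1` — 29000 nM
compound 2 `O=C(CN1CCCC1)Nc1ccc(-c2nc3ccccc3[nH]2)cc1` — 55000 nM
compound 3 `COc1cccc(-c2nc3cc(C(F)(F)F)ccc3[nH]2)c1` — 90000 nM

In an ADME assay on BHK cells (Mesocricetus auratus) for cytotoxicity, read by MTT assay, with a stated time of 96 h (a higher number here means that more compound is tolerated, a lower number that less compound is tolerated), compound 1 gives 29000 nM, the lowest of the three numbers; compound 2 lies closest, and compound 3 furthest. For the measured compounds named here, the only single-point step measured is a 1.9-fold higher number from compound 1 to compound 2 (0.28 log units; within the scatter), which concerns the trifluoromethyl group on the shared core, not the amide side chain. Compound 3 carries a different substitution pattern altogether, so its value and that of compound 1 are simply two numbers with a gap beyond the scatter between them.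

Compound 4 `O=C(O)CCC(=O)Nc1ccc(-c2nc3cc(C(F)(F)F)ccc3[nH]2)cc1` is still to be measured in this assay. It differs from compound 1 by carboxymethyl in place of pyrrolidin-1-yl on a saturated chain carbon bound to a carbonyl carbon. Going by the values given here, no measured step touches this part of the molecule, so there is nothing in the data that sets a direction for the change. The expectation therefore defaults to a step from compound 1 to compound 4 of about a 1.4-fold higher number from compound 1 to compound 4 (0.14 log units; within the scatter), that is, no change beyond the scatter, with a wide range to reflect the lack of precedent. For compound 4 the estimated value is 40000 nM, expected between 15000 nM and 110000 nM.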

Compound 4, half-maximal cytotoxic concentration: > 100000 nM
Compound 4 was reported as a limit; the forecaster's own chance of this, stated with the estimate: 20%; at least 2.5-fold (0.39 log units) between middle value and limit.
By their numbers in this assay, from the lowest: compounds 1, 2 and 3 (each within the scatter of the next, the first and the last beyond it). At a limit, above all of these: compound 4.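

Compound 4 is reported as a limit in this assay, not as a number: the limit of > 100000 nM in this assay, at which 1 of the 4 values shown sits.

For the compounds shown here, on a saturated chain carbon bound to a carbonyl carbon, carboxymethyl in place of pyrrolidin-1-yl gives an at least 3.4-fold higher number from compound 1 to compound 4 (0.53 log units; beyond the scatter), so the amide side chain is a place where the number can move beyond the scatter, which the one earlier step, on the trifluoromethyl group, did not show. This single change removes the pyrrolidine ring and brings in the carboxylic acid together, and the size of the step is known only as a bound.

Which of the two matters stays open: an open-chain amine such as dimethylamino, or the methyl ester of the acid, would separate them. Also open, from the compounds shown here alone, is whether a longer or shorter acid chain, or the acid without trifluoromethyl on the core, stays at the limit.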